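Methoxy for Chloro: Expected Growth Inhibition of Compound 4

A few compounds are considered here, and "the series" means these few. Any claim that something is new, unique, unknown or untested is made for them only; others in the source may bear on it.

Compound 1 `COc1cc2c(/C=C3/C(=O)Nc4ccc(O)cc43)c(Cl)n(Cc3cc(OC)c(OC)c(OC)c3)c2cc1C` gives 33100 nM in a functional assay on cells (Cancer cell lines, Homo sapiens) for cytotoxicity, with a stated time of 48 h; a higher number here means a weaker inhibitor of growth, a lower number a stronger inhibitor of growth.
Compound 2 `COc1c(/C=C2/C(=O)Nc3ccccc32)c2ccccc2n1-c1ccccc1` gives 4070 nM in this assay.
Compound 3 `COc1c(/C=C2/C(=O)Nc3ccc(Cl)cc32)c2ccccc2n1-c1ccccc1` gives 21900 nM in this assay.

Compound 3 stands second highest of the three numbers shown in this assay; compound 1 is its nearest neighbour, within the scatter, and compound 2 its furthest, beyond the scatter. Compound 4 `COc1ccc2c(c1)/C(=C\c1c(OC)n(-c3ccccc3)c3ccccc13)C(=O)N2` differs from compound 3 in one place: methoxy in place of chloro on an aromatic carbon. Among the measured compounds shown here, one measured step bears on this change: a 5.4-fold higher number from compound 2 to compound 3 (0.73 log units; beyond the scatter), where hydrogen gave way to chloro at the same ring carbon, a modest change. For the measured compounds named here, compound 4 removes that chloro again, so part of that step should be undone, but the entering methoxy has no measured counterpart here, and compound 1 carries a hydroxy on its corresponding ring with a high number, so the direction is uncertain. Compound 4 is therefore expected to give 11000 nM, in the range 3500 nM to 35000 nM, a modest lowering estimated as a 2.0-fold lower number from compound 3 to compound 4 (0.30 log units; within the scatter).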

Compound 4, concentration for total growth inhibition: 17400 nM
Compound 4: middle estimate off by 1.6-fold (0.20 log units), on the low side, and the stated range covers the measured number.
By their numbers in this assay, from the lowest: compound 2; then compounds 4, 3 and 1 (each within the scatter of the next).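

In this assay the exchange of chloro for methoxy at this aromatic carbon leaves the number within the scatter (a 1.3-fold lower number from compound 3 to compound 4 (0.10 log units; within the scatter)), so the two groups cannot be told apart here. Among the compounds shown here, the earlier compounds showed only that chloro raised the number over hydrogen (a 5.4-fold higher number from compound 2 to compound 3 (0.73 log units; beyond the scatter)); methoxy now does the same, also beyond the scatter (a 4.3-fold higher number from compound 2 to compound 4 (0.63 log units; beyond the scatter)). Among compounds 2, 3 and 4, then, hydrogen gives the lowest number at this carbon, and neither substituent shown matches it, although this rests on only these three compounds.

As far as these compounds go, whether an amine, a carboxylic acid or a longer chain such as ethoxy at this carbon would also keep the number above that of compound 2 remains open. Nothing shown here explains why either group raises the number.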